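Diethyl in place of methyl on a sulfonamide of a phenoxyacetic acid

The source may report more compounds than this note shows. Statements on the series, on what has been measured and on what is new or still open speak of the compounds shown alone.

Measured so far:
- compound 1, `CCCS(=O)(=O)c1cccc(C#Cc2cc(F)ccc2OCC(=O)O)c1`: 65 nM
- compound 2, `CNS(=O)(=O)c1ccc(C)c(C#Cc2cc(Cl)ccc2OCC(=O)O)c1`: 10 nM

In an assay on CHO cells for displacement of a labelled ligand from prostaglandin D2 receptor 2 (Homo sapiens), read by scintillation counting (on this read-out higher numbers stand for weaker inhibition and lower numbers for stronger inhibition), compound 2 gives the lowest of the two numbers shown; compound 1 sits at a higher number, a gap beyond the usual scatter. Compound 3, `CCN(CC)S(=O)(=O)c1ccc(C)c(C#Cc2cc(Cl)ccc2OCC(=O)O)c1`, is not yet measured. It differs from compound 2 in one place: diethylamino in place of methylamino on a sulfonyl sulfur. Among the compounds with values here, no pair of measured compounds shows this kind of change, so its effect is unknown here. A small weakening beyond the scatter, or none at all, is expected for compound 3, as the step of a 2.0-fold higher number from compound 2 to compound 3 (0.30 log units; within the scatter). Compound 3 is therefore estimated at 20 nM, most likely between 6 nM and 70 nM.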

Compound 3, inhibition constant: 3.4 nM
Estimate against measurement, compound 3: 5.9-fold (0.77 log units) above, and the stated range ends above it.
By their numbers in this assay, from the lowest: compound 3; then compound 2; then compound 1.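

In this assay putting diethylamino in place of methylamino on the sulfonyl sulfur gives a 2.9-fold lower number from compound 2 to compound 3 (0.47 log units; beyond the scatter) and shows that this place takes the larger group without any loss. Strong inhibition here also persists without the hydrogen-bond donor of methylamino, since diethylamino has none. Nothing measured here explains the change. The compounds shown leave open whether losing that donor or adding carbon matters more. Dimethylamino or a pyrrolidine ring on the same sulfur would help to separate these two changes.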